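The source may report more compounds than this note shows. Statements on the series, on what has been measured and on what is new or still open speak of the compounds shown alone.

- compound 1 `CC(C)=CCc1cc(C(=O)Nc2cc3ccc(OCCC4CCCCN4)c(C)c3oc2=O)ccc1O`: 640 nM
- compound 2 `CC(C)=CCc1cc(C(=O)Nc2cc3ccc(OCCCN(C)C(C)C)c(C)c3oc2=O)ccc1O`: 570 nM
- compound 3 `CC(C)=CCc1cc(C(=O)Nc2cc3ccc(OCCCN(C)C4CCCCC4)c(C)c3oc2=O)ccc1O`: 970 nM

These values come from a functional assay on SK-BR-3 cells (Homo sapiens) for antiproliferative activity; a lower number here means a stronger inhibitor, a higher number a weaker inhibitor. Compound 3, at 970 nM, has the highest number of the three, but it cannot be told apart from the others: the measured steps are a 1.5-fold higher number from compound 1 to compound 3 (0.18 log units; within the scatter) and a 1.7-fold higher number from compound 2 to compound 3 (0.23 log units; within the scatter). The remaining step, a 1.1-fold lower number from compound 1 to compound 2 (0.05 log units; within the scatter), is just as small.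

The next compound is compound 4 `CC(C)=CCc1cc(C(=O)Nc2cc3ccc(OCCCNCc4ccccc4)c(C)c3oc2=O)ccc1O`. It has benzylamino in place of cyclohexyl(methyl)amino on a saturated chain carbon, three bonds along the chain from an oxygen on an aromatic ring.

Within the data shown here, no measured compound carries an aromatic ring on its amine, so this change has no direct precedent. The nearest evidence is the swap of isopropyl for cyclohexyl on the amine nitrogen, a 1.7-fold higher number from compound 2 to compound 3 (0.23 log units; within the scatter). Among the measured compounds shown here, compound 1 is also relevant, as the one measured compound with a hydrogen on its amine nitrogen, and its step is a 1.5-fold higher number from compound 1 to compound 3 (0.18 log units; within the scatter). Every change made so far to this amine part has stayed within the scatter, so no step beyond the scatter is expected in this assay.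

The estimated step is a 1.4-fold lower number from compound 3 to compound 4 (0.14 log units; within the scatter). For compound 4 the expected value is 700 nM, with an estimated range from 300 nM to 1600 nM.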

Compound 4, half-maximal inhibitory concentration: 470 nM
The estimate for compound 4 lay 1.5-fold (0.17 log units) above the measured number; the measured number falls inside the stated range.
By their numbers in this assay, from the lowest: compounds 4, 2, 1 and 3 (each within the scatter of the next, the first and the last beyond it).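

In this assay, replacing cyclohexyl(methyl)amino with benzylamino gives a 2.1-fold lower number from compound 3 to compound 4 (0.31 log units; beyond the scatter) and is the only step among these compounds to pass the scatter, though modestly. This separation does not extend to the other amines, since a 1.2-fold lower number from compound 2 to compound 4 (0.08 log units; within the scatter) and a 1.4-fold lower number from compound 1 to compound 4 (0.13 log units; within the scatter) show that an aromatic ring on this side chain can be accommodated without a clear change from those compounds, and compound 4 stands apart only from compound 3. The step from compound 3 to compound 4 changes two things at once, swapping a non-aromatic ring for an aromatic one and placing a hydrogen on the amine nitrogen, and no measurement here explains the difference in activity.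

Benzyl(methyl)amino at the same place would help separate the ring change from the change at the amine hydrogen, and cyclohexylmethylamino would test the ring change while keeping that hydrogen. From the compounds shown here alone, it also remains open whether a substituent such as fluorine on the benzyl ring, or a longer chain in place of the propyl chain, would move the activity further than these small steps.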